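Working notes: cyano in place of hydroxy

The source may hold more compounds than are shown below. What is called first, only, known or untested is meant among the compounds shown, and "the series" means these compounds.

Values measured so far in a functional assay on NCI60 cells (Homo sapiens) for cytotoxicity, with a stated time of 48 h (on this read-out lower numbers stand for stronger inhibition and higher numbers for weaker inhibition), are as follows
- compound 1 `CS(=O)(=O)c1ccc(-c2cncc(-c3cc4ccc(O)cc4[nH]3)c2)cc1` gives 7000 nM
- compound 2 `Oc1ccc(-c2cncc(-c3cc4ccc(O)cc4[nH]3)n2)cc1` gives 4000 nM

Compound 2 stands within the scatter of compound 1, so the two cannot be told apart in this assay on these numbers. The two compounds differ in more than one place, so neither value isolates a single structural change.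

The next compound, compound 3 `N#Cc1ccc(-c2cncc(-c3cc4ccc(O)cc4[nH]3)n2)cc1`, has cyano in place of hydroxy on an aromatic carbon, para to a large group, taking 4-hydroxyphenyl to 4-cyanophenyl (cyano in place of hydroxy on an aromatic carbon). Among the measured compounds shown here, the data hold no measured precedent for this swap, so the expectation rests only on the level set by compound 2 (4000 nM) and compound 1 (7000 nM). The expected result is a 1.3-fold higher number from compound 2 to compound 3 (0.10 log units; within the scatter) and so a small drift toward a higher number, with nothing beyond the scatter. With so little to go on, the range is kept wide on both sides. For compound 3 the estimated value is 5000 nM with an expected range from 1500 nM to 15000 nM (an estimate only).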

Compound 3, half-maximal inhibitory concentration: 9000 nM
Beside the measured number, compound 3's estimate is 1.8-fold (0.26 log units) below it; the range from low to high includes it.
By their numbers in this assay, from the lowest: compounds 2, 1 and 3 (each within the scatter of the next, the first and the last beyond it).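

The change from 4-hydroxyphenyl to 4-cyanophenyl gives the series its first comparison that differs in one place only: a 2.3-fold higher number from compound 2 to compound 3 (0.35 log units; beyond the scatter) in this assay, a modest move but one that the earlier pair of compounds could not show. This position on the aromatic ring therefore responds to the group it carries, and of these two groups hydroxy gives the lower number, with the change taking away a hydrogen-bond donor and keeping a hydrogen-bond acceptor. No measurement at hand bears on why the number moves in this direction.

A single pair cannot separate the loss of the hydrogen-bond donor from the arrival of cyano, and it cannot show whether the step would hold on another core. Methoxy, an amine or a carboxylic acid at the same place, para to the large group, would help to tell these readings apart, and would show whether hydroxy keeps the lower number against groups other than cyano.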